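The compounds below may be only part of what the source reports. "The series", "measured", "known", "first", "only" and "open" are said of these compounds alone.

Of the compounds shown here, three of one shared core have been measured. Compound 1 `CCn1c(=O)/c(=C2\Sc3ccc(C)cc3N2C)s/c1=C\c1ccncc1Nc1ccccc1Cl` gives 350 nM in a functional assay on CWR22R cells (Homo sapiens) for inhibition; a higher number here means a weaker inhibitor, a lower number a stronger inhibitor. Compound 2 `CCn1c(=O)/c(=C2\Sc3ccc(OC)cc3N2C)s/c1=C\c1ccncc1Nc1ccccc1C` gives 410 nM in this assay. Compound 3 `CCn1c(=O)/c(=C2\Sc3ccc(OC)cc3N2C)s/c1=C\c1ccncc1Nc1ccccc1Cl` gives 500 nM in this assay, the highest number of the three, though its gaps to compound 1 and compound 2 both lie within the scatter, so the three cannot be ranked.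

Compound 4 `CCn1c(=O)/c(=C2\Sc3ccc(OC)cc3N2C)s/c1=C\c1ccncc1Nc1ccccc1F` differs from compound 3 in one place: fluoro in place of chloro on an aromatic carbon.

Among the compounds with values here, two measured steps bear on this. The step from compound 2 to compound 3, which exchanged a group at this same aromatic carbon, was a 1.2-fold higher number from compound 2 to compound 3 (0.09 log units; within the scatter). The step from compound 1 to compound 3, a change elsewhere on the core, was a 1.4-fold higher number from compound 1 to compound 3 (0.15 log units; within the scatter). Neither exchange moved the number beyond the scatter, so a further swap at the same carbon is expected to give no change at the digits printed from compound 3 to compound 4 (within the scatter), with no direction favoured. Compound 4 is therefore expected to give about 500 nM, with a range from 250 nM to 1000 nM.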

Compound 4, half-maximal inhibitory concentration: 190 nM
The estimate for compound 4 lay 2.6-fold (0.42 log units) above the measured number; measured number below the stated range.
By their numbers in this assay, from the lowest: compounds 4, 1, 2 and 3 (each within the scatter of the next, the first and the last beyond it).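

At this aromatic carbon, the exchange of chloro and methyl had left the number within the scatter, but the group there does matter in this assay: fluoro in place of chloro gives a 2.6-fold lower number from compound 3 to compound 4 (0.42 log units; beyond the scatter), and fluoro in place of methyl gives a 2.2-fold lower number from compound 2 to compound 4 (0.33 log units; beyond the scatter). Of the three groups seen at this carbon, only fluoro separates from the others, so the earlier flat result came from the particular pair compared and does not describe the position as a whole. Nothing at hand gives a reason for this difference.

Still open, from the compounds shown here alone, is whether a hydrogen, a hydroxyl or an amine at this carbon would give a lower or a higher number than fluoro. Also open, going by these compounds, is whether the fluoro result carries over to compound 1, which has methyl where compound 4 has methoxy.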